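Acylating the piperazine nitrogen of a purine-based TLR9 antagonist

The compounds below may be only part of what the source reports. "The series", "measured", "known", "first", "only" and "open" are said of these compounds alone.

Compound 3 `CCN1CCN(CCCn2cnc3c(N4CCN(CC)CC4)nc(NCc4ccc(F)cc4)nc32)CC1` is one of three related molecules tested in an assay on HEK293 cells for antagonist activity at Toll-like receptor 9 (Homo sapiens), read by spectrophotometry; a lower number here means a stronger inhibitor, a higher number a weaker inhibitor. In this assay compound 3 gives 470 nM, the second highest of the three numbers. Its closest neighbour is compound 2 `CCN1CCN(CCCn2cnc3c(N4CCN(C5CCCC5)CC4)nc(NCc4ccc(F)cc4)nc32)CC1`, which in this assay gives 250 nM; the difference a 1.9-fold higher number from compound 2 to compound 3 (0.27 log units; within the scatter) is too small to read as a real change. The remaining compound 1 `CCN1CCN(CCCn2cnc3c(N4CCN(C(=O)C5CCCC5)CC4)nc(NCc4ccc(N(CC)CC)cc4)nc32)CC1` gives 8800 nM in this assay, a far weaker result, but it differs from compound 3 in two places at once, on the ring nitrogen and on the benzylic aromatic ring, so its value cannot be assigned to either change alone.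

Compound 4 `CCN1CCN(CCCn2cnc3c(N4CCN(C(=O)C5CCCC5)CC4)nc(NCc4ccc(F)cc4)nc32)CC1` has not yet been measured. It differs from compound 3 by cyclopentylcarbonyl in place of ethyl on an amine nitrogen in a ring. Among the measured compounds shown here, no measured pair isolates this exact change: the only single step, from ethyl to cyclopentyl, stayed within the scatter, while the carbonyl-bearing group appears only in compound 1. Because compound 1 gives 8800 nM, the carbonyl group is tentatively expected to weaken inhibition, so the step of a 4.3-fold higher number from compound 3 to compound 4 (0.63 log units; beyond the scatter) is estimated to be a rise. For compound 4 the estimated value in this assay is 2000 nM, within a range of 500 nM to 8000 nM.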

Compound 4, half-maximal inhibitory concentration: > 30000 nM
Compound 4: only a limit was reported (the forecaster's own chance of this, stated with the estimate: 5%); at least 15-fold (1.17 log units) between middle value and limit.
By their numbers in this assay, from the lowest: compounds 2 and 3 (each within the scatter of the next); then compound 1. At a limit, above all of these: compound 4.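

In this assay the reading for compound 4 is a limit and not a number: the limit of > 30000 nM in this assay, at which 1 of the 4 values shown sits. Its steps are therefore lower bounds, yet they are large, and the clearest is an at least 120-fold higher number from compound 2 to compound 4 (2.07 log units; beyond the scatter), where the five-membered carbon ring stays and only a carbonyl is added on the amine nitrogen in a ring; an at least 63-fold higher number from compound 3 to compound 4 (1.80 log units; beyond the scatter) points the same way, whereas swapping the two groups without a carbonyl gave only a 1.9-fold higher number from compound 2 to compound 3 (0.27 log units; within the scatter), so this position tolerates ethyl and cyclopentyl but not cyclopentylcarbonyl, at least in these compounds. With cyclopentylcarbonyl held fixed, the other end of the molecule also counts, as fluoro in place of diethylamino on an aromatic carbon gives an at least 3.4-fold higher number from compound 1 to compound 4 (0.53 log units; beyond the scatter), which shows that the loss seen with this group depends on what the aromatic ring carries.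

As far as these compounds go, whether a smaller acyl group such as acetyl, or a methylsulfonyl group, would behave like cyclopentylcarbonyl on this nitrogen stays open. Also open, from the compounds shown here alone, is whether an aromatic substituent other than fluoro or diethylamino, such as methoxy, would change the outcome, and how far compound 4 really lies past its limit.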